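The source may report more compounds than this note shows. Statements on the series, on what has been measured and on what is new or still open speak of the compounds shown alone.

Measured so far:
- compound 1 `COC(=O)c1ccc(OCCCCOc2ccc(C(=O)CC3CCCC3)c(O)c2C)cc1`: 12.2%
- compound 2 `Cc1c(OCCCCOc2ccc(C(=O)O)cc2Cl)ccc(C(=O)CC2CCCC2)c1O`: 82.2%

In an assay on HEK293 cells for positive allosteric modulation of metabotropic glutamate receptor 2 (Rattus norvegicus), read by thallium flux, with a stated time of 2.5 min (a lower number here means a smaller maximal response, a higher number a larger maximal response), compound 1 gives 12.2%, the lowest of the two numbers. Among the compounds with values here, the only other measured compound, compound 2, gives 82.2% in this assay, and the single measured step, a number 70 percentage points higher from compound 1 to compound 2 (beyond the scatter), changes the aryl end of the chain: 4-carboxy-2-chlorophenyl in place of 4-(methoxycarbonyl)phenyl on an oxygen on a saturated carbon.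

Compound 3 `COC(=O)c1ccc(OCCCCOc2ccc(C(=O)CC3CCCC3)c(C)c2C)cc1` keeps that aryl end of compound 1 unchanged and instead alters the other ring of the shared core: methyl in place of hydroxy on an aromatic carbon. Within the data shown here, no measured step touches this position, so the large step seen between compound 1 and compound 2 gives no direct guide here, and the direction of the change is open. With nothing to support a shift, the step of a number 2.8 percentage points higher from compound 1 to compound 3 (within the scatter) is expected to stay small, with a wide margin toward larger responses. Compound 3 is therefore estimated at 15% in this assay, within a range of 3% to 45%.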

Compound 3, largest response reached (reported as percent of maximum), in percent of the reference or control that the assay uses: 14.1%
Compound 3: middle estimate off by 0.9 percentage points, on the high side; the measured number falls inside the stated range.
By their numbers in this assay, from the lowest: compounds 1 and 3 (each within the scatter of the next); then compound 2.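

This position now has its first direct reading: in this assay, a number 1.9 percentage points higher from compound 1 to compound 3 (within the scatter). The swap removes the hydroxy group, with its hydrogen-bond donor and acceptor, and puts in a methyl group, which has neither, yet the two numbers stay within the scatter of each other, so with the 4-(methoxycarbonyl)phenyl end in place, the assay separates neither group from the other. Nothing available here offers an explanation for this result.

The compounds shown leave open whether the same swap would hold with the 4-carboxy-2-chlorophenyl end of compound 2, where the response is much larger and a change might be easier to see. Also open, on these data alone, is what a methoxy or an amino group would give on this same aromatic carbon.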